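Trading Methoxy for Ethyl on the Amide Nitrogen

A few compounds are considered here, and "the series" means these few. Any claim that something is new, unique, unknown or untested is made for them only; others in the source may bear on it.

Among the measured compounds shown here, compound 2 `CON(C)C(=O)/C=C1\CCc2ccc(F)cc21` gives 6% in a functional assay on the whole organism with Rattus norvegicus as the target, at a dose of 20 mg/kg by the oral route (a higher number here means more inhibition at the dose given (going by the name of the read-out), a lower number less inhibition), the lower of the two values measured so far, while compound 1 `CNC(=O)/C=C1\CCc2ccc(F)cc21` gives 45%. Compound 3 `CCN(C)C(=O)/C=C1\CCc2ccc(F)cc21` awaits measurement; it differs from compound 2 by ethyl in place of methoxy on an amide-type nitrogen. For the measured compounds named here, the only measured step, a number 39 percentage points lower from compound 1 to compound 2 (beyond the scatter), put methoxy where hydrogen had been on that same nitrogen, so it bears on this change only loosely, and no measured step shows what an ethyl does there. A partial recovery is expected for compound 3, in the step of a number 12 percentage points higher from compound 2 to compound 3 (beyond the scatter), though not back to the level of compound 1. Compound 3 is therefore estimated at 18%, within a range from 0% to 40%.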

Compound 3, a percentage reported as inhibition, in the whole organism at one dose (the size of the read-out at that dose, not a potency): 20%
Beside the measured number, compound 3's estimate is 2 percentage points below it; the measured number falls inside the stated range.
By their numbers in this assay, from the lowest: compound 2; then compound 3; then compound 1.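

In this assay, ethyl on this amide-type nitrogen gives a number 14 percentage points higher from compound 2 to compound 3 (beyond the scatter), so methoxy and ethyl, though equal in heavy atoms, are not interchangeable here. Ethyl in place of the amide hydrogen still gives a number 25 percentage points lower from compound 1 to compound 3 (beyond the scatter), so both groups tested on this nitrogen sit under the hydrogen compound. Nothing at hand explains the gap between them.

Still open, going by these compounds, is whether a longer chain such as propyl would lower the number further. It is also unknown whether a chain ending in an amine or a carboxylic acid would bring it back toward compound 1.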